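From compound 1 to compound 3: one group exchanged

The source may hold more compounds than are shown below. What is called first, only, known or untested is meant among the compounds shown, and "the series" means these compounds.

Measured compounds in a physicochemical assay for solubility, read by HPLC, in simulated intestinal fluid, with a stated time of 16 h, at pH 6.5 (on this read-out higher numbers stand for higher solubility and lower numbers for lower solubility), so far:
- compound 1 `CNC(=O)c1cc(C(=O)N[C@H]2CC[C@H](O)CC2)c([C@@H](C)c2cccc(Cl)c2)o1` gives 408 ug/mL
- compound 2 `CNC(=O)c1cc(C(=O)N[C@H]2[C@@H]3COC[C@@H]32)cc2c1O[C@H](CF)[C@H]2c1ccccc1` gives 85 ug/mL

Of these two, compound 1 stands highest (408 ug/mL), and compound 2 (85 ug/mL) lies lower by a margin beyond the usual scatter. Compound 3 `CNC(=O)c1cc(C(=O)N[C@H]2CC[C@H](O)CC2)c([C@@H](C)c2ccc(C)cc2)o1` still awaits its measurement in this assay and departs from compound 1 at one place (4-methylphenyl in place of 3-chlorophenyl on a saturated chain carbon bound to an aromatic carbon and a saturated chain carbon), with 4-methylphenyl in place of 3-chlorophenyl on a saturated chain carbon bound to an aromatic carbon and a saturated chain carbon. For the measured compounds named here, no measured pair shows this exchange, and compound 2 differs from compound 1 in more than one place, so the data offer only weak guidance. A small downward step, probably within the scatter, is expected (a 1.3-fold lower number from compound 1 to compound 3 (0.11 log units; within the scatter)). Compound 3 is estimated at 320 ug/mL within an expected range (130 ug/mL to 700 ug/mL).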

Compound 3, solubility: > 1000 ug/mL
Compound 3 ended at the assay's limit; the forecaster's own chance of this, stated with the estimate: 5%; at least 3.1-fold (0.49 log units) between middle value and limit.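

In this assay, for the compounds shown here, 4-methylphenyl in place of 3-chlorophenyl on a saturated chain carbon bound to an aromatic carbon and a saturated chain carbon gives an at least 2.4-fold higher number from compound 1 to compound 3 (0.38 log units; beyond the scatter), the first reading of any exchange at this place. Compound 3 gives > 1000 ug/mL, which is a limit of the assay and not a number. The step therefore has only a lower bound, and its full size cannot be read: the limit of > 1000 ug/mL in this assay, at which 1 of the 3 values shown sits.

The exchange alters both the substituent and its numbered position on the phenyl group, and the compounds shown do not separate the two, which 3-methylphenyl or 4-chlorophenyl at this place would do. As far as these compounds go, how a 4-aminophenyl or a 4-carboxyphenyl would read in this assay also remains open.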